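Methyl to Methoxy: Expecting a Small Step

The source may hold more compounds than are shown below. What is called first, only, known or untested is meant among the compounds shown, and "the series" means these compounds.

Three measured compounds share one core and differ only in what sits on the six-membered aromatic ring of carbon only. In an assay on isolated protein for inhibition of Dopamine beta-hydroxylase (Rattus norvegicus) (on this read-out higher numbers stand for weaker inhibition and lower numbers for stronger inhibition), compound 1 `Cc1ccccc1Cn1cc[nH]c1=S` gives 339000 nM, the highest of the three numbers. Compound 2 `S=c1[nH]ccn1Cc1cc(Cl)ccc1Cl` gives 97700 nM in this assay, and compound 3 `S=c1[nH]ccn1Cc1ccc(Br)cc1` gives 115000 nM. Both numbers lie below that of compound 1 by more than the usual scatter, so compound 1 is the weakest inhibitor of the three on this read-out.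

For the measured compounds named here, no pair among the measured compounds differs in one place only, so no single step can be read off from them. Compound 4 `COc1ccccc1Cn1cc[nH]c1=S` forms such a pair with compound 1: it differs from compound 1 by methoxy in place of methyl on an aromatic carbon. Going by the values given here, nothing among the measured compounds shows what this replacement does, and compounds 2 and 3 carry halogens rather than a methoxy, so they give no guide. For compound 4 the step from compound 1 is expected to be small, a 1.4-fold lower number from compound 1 to compound 4 (0.13 log units; within the scatter), leaning toward a lower number but possibly no further than the scatter. Compound 4 is therefore estimated at 250000 nM in this assay, with a range from 100000 nM to 600000 nM.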

Compound 4, half-maximal inhibitory concentration: 74100 nM
Compound 4: the middle estimate sits 3.4-fold (0.53 log units) above what was measured; measured number outside the range, below it.
By their numbers in this assay, from the lowest: compounds 4, 2 and 3 (each within the scatter of the next); then compound 1.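

Replacing methyl with methoxy on an aromatic carbon, ortho to a group of 7 heavy atoms, proved more than a neutral swap in this assay, giving a 4.6-fold lower number from compound 1 to compound 4 (0.66 log units; beyond the scatter) as a modest step that lies beyond the scatter. For the compounds shown here, this is the first change in the set made in one place only, and it shows that the group at this position has a measurable bearing on the number, something compounds 2 and 3 could not show, as each differs from compound 1 in more than one place. Nothing given here accounts for the lower number, so the step stands as an observation without an explanation.

The compounds shown leave open whether the lower number follows from the oxygen itself or from the larger group, a question that a hydroxyl or an ethyl group on the same carbon, or a longer ether such as ethoxy, would help to separate. They also leave open whether methoxy in place of methyl would give a step of similar size on a ring that also carries chlorine or bromine, as the rings of compounds 2 and 3 do.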